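Acylsulfonamide Replacing Hydroxymethyl: Expected Fall in Free Fraction

The compounds below may be only part of what the source reports. "The series", "measured", "known", "first", "only" and "open" are said of these compounds alone.

Three compounds sharing one core were measured in an ADME assay on the whole organism (plasma, Macaca fascicularis) for protein binding, read by LC-MS, using equilibrium dialysis and cassette dosing, with a stated time of 24 h, at a dose of 1 mg/kg by the oral route; on this read-out higher numbers stand for a larger free fraction and lower numbers for a smaller free fraction. Compound 3 `CCCCN(c1nc2c(CO)cccc2o1)[C@H](C)c1ccc(-c2ccccc2-c2nnn[nH]2)cc1` gives 0.00112, the largest number among the three, though compound 2 `CCCCN(c1nc2c(C(=O)NC)cccc2o1)[C@H](C)c1ccc(-c2ccccc2-c2nnn[nH]2)cc1`, at 0.000975, sits within the scatter of it (a 1.1-fold higher number from compound 2 to compound 3 (0.06 log units; within the scatter)). Compound 1 `CCCCN(c1nc2c(NS(C)(=O)=O)cccc2o1)[C@H](C)c1ccc(-c2ccccc2-c2nnn[nH]2)cc1` gives 0.000203, and the step of a 5.5-fold higher number from compound 1 to compound 3 (0.74 log units; beyond the scatter) is beyond the scatter, as is a 4.8-fold higher number from compound 1 to compound 2 (0.68 log units; beyond the scatter). Compound 4 `CCCCN(c1nc2c(C(=O)NS(C)(=O)=O)cccc2o1)[C@H](C)c1ccc(-c2ccccc2-c2nnn[nH]2)cc1` differs from compound 3 in one place: (methylsulfonyl)carbamoyl in place of hydroxymethyl on an aromatic carbon. Within the data shown here, the step that bears on this is a 5.5-fold higher number from compound 1 to compound 3 (0.74 log units; beyond the scatter), the only measured change involving a sulfonyl group, and it ran in the opposite direction. Because compound 1 gave 0.000203, compound 4 is expected to land nearer that value, with an estimated step of a 3.7-fold lower number from compound 3 to compound 4 (0.57 log units; beyond the scatter). The estimate for compound 4 is 0.0003, ranging from 0.0001 to 0.0009.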

Compound 4, unbound fraction: 0.00103
For compound 4 the middle estimate is 3.4-fold (0.54 log units) below the measured one; the measured number lies above the stated range.
By their numbers in this assay, from the lowest: compound 1; then compounds 2, 4 and 3 (each within the scatter of the next).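

In this assay, (methylsulfonyl)carbamoyl on this aromatic carbon stays level with hydroxymethyl, a 1.1-fold lower number from compound 3 to compound 4 (0.04 log units; within the scatter), and methylsulfonyl on the amide-type nitrogen stays level with methyl, a 1.1-fold higher number from compound 2 to compound 4 (0.02 log units; within the scatter). A sulfonyl group at this position therefore does not in itself go with the small free fraction of compound 1, which stands apart, a 5.1-fold higher number from compound 1 to compound 4 (0.71 log units; beyond the scatter). Nothing available explains this result.

Still open, from the compounds shown here alone, is whether a carboxylic acid or a primary amine on this carbon would match compound 4 or compound 1. Going by these compounds, it is also open whether a longer chain in place of the sulfonyl methyl would leave the number unchanged.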